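Sulfated fragments against fibroblast growth factor 2

The source may hold more compounds than are shown below. What is called first, only, known or untested is meant among the compounds shown, and "the series" means these compounds.

The two larger, heavily sulfated structures compound 1 `O=S(=O)(O)OC[C@@H]1O[C@@H](O[C@H]2[C@H](OS(=O)(=O)O)[C@H](OS(=O)(=O)O)C(OS(=O)(=O)O)O[C@H]2COS(=O)(=O)O)[C@@H](OS(=O)(=O)O)[C@H](OS(=O)(=O)O)[C@H]1OS(=O)(=O)O` and compound 2 `O=S(=O)(O)OC[C@@H]1O[C@H](O[C@H]2[C@H](OS(=O)(=O)O)[C@H](OS(=O)(=O)O)C(OS(=O)(=O)O)O[C@H]2COS(=O)(=O)O)[C@@H](OS(=O)(=O)O)[C@H](OS(=O)(=O)O)[C@H]1OS(=O)(=O)O` set the reference. In an assay on isolated protein with fibroblast growth factor 2 (Homo sapiens) as the target (on this read-out lower numbers stand for tighter binding and higher numbers for weaker binding), compound 1 gives 13300 nM and compound 2 gives 6300 nM; the step of a 2.1-fold lower number from compound 1 to compound 2 (0.32 log units; beyond the scatter) rests on the single place where the drawings differ, (the fact that one of compounds 1 and 2 is drawn with a defined configuration and the other without, at the place where they differ). The much smaller fragment compound 3 `CO[C@@H]1CCO[C@H](COS(=O)(=O)O)C1OS(=O)(=O)O` stands far behind both: in this assay compound 3 gives 17400000 nM, the highest number of the three and beyond the scatter from either of the larger compounds.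

Compound 4 `O=S(=O)(O)OC[C@H]1OCC[C@@H](OCCCOc2ccccc2)C1OS(=O)(=O)O` keeps the core of compound 3 and differs by 2-phenoxyethyl in place of hydrogen on a saturated chain carbon bound to an oxygen on a saturated carbon. Within the data shown here, no measured step bears on this change: the only step in hand, from compound 1 to compound 2, concerns a drawn configuration in the larger pair and says nothing about a 2-phenoxyethyl added to the small fragment. The wide gap between compound 3 and the larger compounds offers no reading for such an addition either. The expectation for compound 4 is therefore held close to compound 3, with a broad range: in this assay compound 4 is estimated at 6000000 nM, between 1200000 nM and 25000000 nM, a step of a 2.9-fold lower number from compound 3 to compound 4 (0.46 log units; beyond the scatter) that is expected to be modest and possibly within the scatter.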

Compound 4, dissociation constant: 7500000 nM
Compound 4: the middle estimate sits 1.3-fold (0.10 log units) below what was measured, and the stated range covers the measured number.
By their numbers in this assay, from the lowest: compound 2; then compound 1; then compound 4; then compound 3.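

In this assay, 2-phenoxyethyl in place of hydrogen on a saturated chain carbon bound to an oxygen on a saturated carbon gives a 2.3-fold lower number from compound 3 to compound 4 (0.37 log units; beyond the scatter). Among these compounds, this is the first reading at this position: the small fragment can carry a substantial group with a six-membered aromatic ring of carbon only, and the number moves modestly towards tighter binding rather than weaker, whereas the earlier step within the larger pair concerned only a drawn configuration. Among the compounds shown here, nothing in hand explains this step, since the only supporting information relates to the larger pair and has no bearing on the added group.

The compounds shown leave open which part of 2-phenoxyethyl carries the step, the aromatic ring, the ether oxygen or the chain itself, and whether a longer chain, a carboxylic acid or an amine at the same place would move the number further or reverse it. They also leave open whether the same addition would give a step of similar size on the core of compound 1 or compound 2.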